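The source may hold more compounds than are shown below. What is called first, only, known or untested is meant among the compounds shown, and "the series" means these compounds.

Measured so far:
compound 1 `O=C(NNc1cccc(Cl)c1)c1cccc(NS(=O)(=O)c2cnc(O)nc2O)c1` — 8040 nM
compound 2 `Cc1ccccc1NNC(=O)c1ccccc1NS(=O)(=O)c1cnc(O)nc1O` — > 20000 nM

In a functional assay on OVCAR-3 cells (Homo sapiens) for antiproliferative activity, read by MTT assay, with a stated time of 24 h (a higher number here means a weaker inhibitor, a lower number a stronger inhibitor), compound 1 gives 8040 nM. Going by these compounds, for compound 2 the assay gives only a limit, > 20000 nM, so its true strength is unknown beyond that point; compound 2 sits at the limit (the limit of > 20000 nM in this assay, at which 1 of the 2 values shown sits). Compound 3 `O=C(NNC(=O)c1ccccc1NS(=O)(=O)c1cnc(O)nc1O)c1ccccc1F` differs from compound 2 by one change: (2-fluorophenyl)carbonyl in place of 2-methylphenyl on an amine nitrogen. With compound 2 known only as a limit, the step in this assay cannot be sized; compound 3 is expected to remain weak, with the step of an at least 1.3-fold lower number from compound 2 to compound 3 (0.12 log units; that floor lies within the scatter) judged likely no larger than the scatter. The estimate for compound 3 is 15000 nM, between 5000 nM and 40000 nM.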

Compound 3, half-maximal inhibitory concentration: 15300 nM
Estimate against measurement, compound 3: 1.0-fold (0.01 log units) below, and the stated range covers the measured number.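

In this assay compound 3 gives 15300 nM as a measured number, with (2-fluorophenyl)carbonyl in place of 2-methylphenyl on the amine nitrogen. The change is an at least 1.3-fold lower number from compound 2 to compound 3 (0.11 log units; that floor lies within the scatter) and so this floor alone shows no clear gain. The true size of the step cannot be read because compound 2 is known only as a limit: the limit of > 20000 nM in this assay, at which 1 of the 3 values shown sits.

Going by these compounds, the carbonyl and the fluorine enter together in one change, so their separate contributions stay open. On these data alone, what a carboxylic acid or a longer chain would give on that amine nitrogen also stays open.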